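The compounds below may be only part of what the source reports. "The series", "measured", "known", "first", "only" and "open" are said of these compounds alone.

Compound 3 `Cc1cc(OCCCCOc2ccc(C(=O)CC3CCCC3)c(O)c2C)ccc1C(=O)O` carries, on one end of the four-carbon linker, the 4-carboxy-3-methylphenyl group. In an ADME assay on a cell-free system (plasma, Rattus norvegicus) for metabolic stability, read by LC-MS, with a stated time of 60 min, tested at 100 uM (on this read-out lower numbers stand for a less stable compound and higher numbers for a more stable compound), compound 3 gives 114%, the second highest of the three numbers recorded. Its nearest neighbour is compound 1 `Cc1c(OCCCCOc2ccc(C(=O)O)cc2Cl)ccc(C(=O)CC2CCCC2)c1O`, which in this assay gives 120%; the step of a number 6 percentage points lower from compound 1 to compound 3 (within the scatter) lies within the scatter, so the two cannot be told apart. The furthest is compound 2 `COc1ccc(C(=O)O)cc1OCCCCOc1ccc(C(=O)CC(C)C)c(O)c1C`, which in this assay gives 99%, a gap beyond the scatter, although compound 2 also differs in the ketone side chain and in the ring on the ether oxygen.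

Compound 4 `Cc1c(OCCCCOc2ccc(C(=O)O)cc2F)ccc(C(=O)CC2CCCC2)c1O` is reached from compound 3 by the change (4-carboxy-2-fluorophenyl in place of 4-carboxy-3-methylphenyl on an oxygen on a saturated carbon). Among the measured compounds shown here, the one measured step that bears on this is the one from compound 1 to compound 3, where the same ether-bound aryl group was exchanged, and it stayed within the scatter. On that basis the step from compound 3 to compound 4 is expected to be a number 1 percentage points higher from compound 3 to compound 4 (within the scatter), with no movement beyond the scatter. Compound 4 is therefore estimated at 115% in this assay, within a range from 100% to 130%.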

Compound 4, percent of the compound remaining: 97%
Compound 4: middle estimate off by 18 percentage points, on the high side, outside the stated range (below it).
By their numbers in this assay, from the lowest: compounds 4 and 2 (each within the scatter of the next); then compounds 3 and 1 (each within the scatter of the next).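

In this assay, among the compounds shown here, the place on an oxygen on a saturated carbon proves able to move the number: the exchange of 4-carboxy-3-methylphenyl for 4-carboxy-2-fluorophenyl gives a number 17 percentage points lower from compound 3 to compound 4 (beyond the scatter) and so goes beyond the scatter, which the only earlier step at this place did not do. The sharper finding comes from the pair that differs in a single atom on that ring, as fluoro in place of chloro on an aromatic carbon gives a number 23 percentage points lower from compound 1 to compound 4 (beyond the scatter) with the rest of the molecule unchanged, so the choice of halogen alone is enough to separate the two compounds in this read-out. Nothing in the data shown offers a reason for either step.

Going by these compounds, it remains open whether the lower number goes with fluoro in particular, or whether bromo, methoxy or a plain hydrogen on the same aromatic carbon would fall with it or stay with chloro. Also open, on these data alone, is whether the fluoro for chloro exchange has the same size with the other ketone side chain of compound 2, and what a methyl ester or an amide in place of the carboxylic acid would do.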